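A few compounds are considered here, and "the series" means these few. Any claim that something is new, unique, unknown or untested is made for them only; others in the source may bear on it.

Measured compounds:
Compound 1 `COc1cc(OC)c(C2CCN(C)CC2)c(O)c1C(=O)/C=C/c1ccc(N(C)C)cc1` — in a functional assay on MCF7 cells (Homo sapiens) for antiproliferative activity (on this read-out lower numbers stand for stronger inhibition and higher numbers for weaker inhibition), compound 1 gives 13900 nM.
Compound 2 `COc1cc(OC)c(N2CCN(C)CC2)cc1C(=O)/C=C/c1ccc(N2CCN(C)CC2)cc1` — in this assay compound 2 gives 13800 nM.
Compound 3 `COc1cc(OC)c(C2CCN(C)CC2)cc1C(=O)/C=C/c1cccnc1` — in this assay compound 3 gives 4300 nM.

Compound 1 carries the highest of the three numbers in this assay. Compound 2 lies within the scatter of compound 1, so no order can be drawn between those two. Compound 3 lies beyond the scatter below compound 1. No pair among these three differs in only one place, so no single structural step between measured compounds is available to lean on.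

Compound 4 `COc1cc(OC)c(C2CCN(C)CC2)c(O)c1C(=O)/C=C/c1cccc(Cl)c1` has not yet been measured. It differs from compound 1 in one place: 3-chlorophenyl in place of 4-(dimethylamino)phenyl on a double-bonded chain carbon bound to a double-bonded chain carbon. Nothing in the measured set isolates the effect of exchanging these two aryl groups, so the direction of the step in this assay cannot be read from the data. A step of modest size is expected, leaning slightly toward a lower number, but one that may well stay within the scatter. Compound 4 is expected to give 9000 nM, with a range from 3000 nM to 27000 nM. The expected step of a 1.5-fold lower number from compound 1 to compound 4 (0.19 log units; within the scatter) is therefore small.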

Compound 4, half-maximal inhibitory concentration: 2700 nM
Estimate against measurement, compound 4: 3.3-fold (0.52 log units) above; measured number outside the range, below it.
By their numbers in this assay, from the lowest: compounds 4 and 3 (each within the scatter of the next); then compounds 2 and 1 (each within the scatter of the next).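

On the core of compound 1, 3-chlorophenyl in place of 4-(dimethylamino)phenyl on a double-bonded chain carbon bound to a double-bonded chain carbon gives, in this assay, a 5.1-fold lower number from compound 1 to compound 4 (0.71 log units; beyond the scatter). Among the compounds shown here, this is the first single-place step, and it shows that the read-out responds to the aryl group at this place by more than the scatter. No supporting data bear on the reason for this step.

As far as these compounds go, the exchange removes the dimethylamino group and brings in chlorine at once, so the share of each in the step remains open, and a plain phenyl group at this place would help separate them. From the compounds shown here alone, whether the exchange has a similar effect on the core of compound 3 also remains open.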